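Chloro to hydrogen on the anilide-side ring: working notes

A few compounds are considered here, and "the series" means these few. Any claim that something is new, unique, unknown or untested is made for them only; others in the source may bear on it.

Measured in a physicochemical assay for solubility; a lower number here means a less soluble compound, a higher number a more soluble compound:
- compound 1 `O=C(Nc1ccccc1Cl)c1cc(Cl)ccc1O`: 5 ug/mL
- compound 2 `N#Cc1ccc(NC(=O)c2cc(Cl)ccc2O)c(Cl)c1`: < 1 ug/mL (a limit)
- compound 3 `O=C(Nc1ccc(F)cc1Cl)c1cc(Cl)ccc1O`: 1.2 ug/mL

Compound 3 gives 1.2 ug/mL, the lower of the two actual numbers in the series, and compound 1 is the nearest at 5 ug/mL. Compound 2 reports < 1 ug/mL, which is a limit of the assay and not a number. The comparison gives an at least 1.2-fold higher number from compound 2 to compound 3 (0.07 log units; that floor lies within the scatter), so no order can be drawn between those two.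

The next compound is compound 4 `O=C(Nc1ccc(F)cc1)c1cc(Cl)ccc1O`, which has hydrogen in place of chloro on an aromatic carbon, ortho to a large group and meta to a fluoro group (hydrogen in place of chloro on an aromatic carbon). Among the compounds with values here, no measured step makes this exact change. The nearest evidence is the two measured steps that replace a hydrogen with a new group: fluoro gave a 4.2-fold lower number from compound 1 to compound 3 (0.62 log units; beyond the scatter), and cyano gave an at least 5.0-fold lower number from compound 1 to compound 2 (0.69 log units; beyond the scatter). Within the data shown here, both lowered the number in this assay, and no measured compound goes against that, though the series is small and neither step involves chloro. A change back to hydrogen is therefore expected to raise the number by a modest amount of similar size, with real uncertainty. The expected change is a 2.1-fold higher number from compound 3 to compound 4 (0.32 log units; beyond the scatter). Compound 4 is estimated at 2.5 ug/mL, with an expected range of 0.9 ug/mL to 8 ug/mL.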

Compound 4, solubility: 1.6 ug/mL
Compound 4: the middle estimate sits 1.6-fold (0.19 log units) above what was measured; the measured number falls inside the stated range.
By their numbers in this assay, from the lowest: compounds 3 and 4 (each within the scatter of the next); then compound 1. At a limit, below all of these: compound 2.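

In this assay, hydrogen in place of chloro on an aromatic carbon, ortho to a large group and meta to a fluoro group, gives a 1.3-fold higher number from compound 3 to compound 4 (0.12 log units; within the scatter). Within the data shown here, this is the first step to involve chloro, and unlike the fluoro step, a 4.2-fold lower number from compound 1 to compound 3 (0.62 log units; beyond the scatter), and the cyano step, an at least 5.0-fold lower number from compound 1 to compound 2 (0.69 log units; beyond the scatter), it stays within the scatter, so with the fluoro group in place, this exchange shows no readable effect on the read-out of this assay. The value of compound 2 is a limit of the assay and not a number, and that limit is the only floor shown for the series: the limit of < 1 ug/mL in this assay, at which 1 of the 4 values shown sits.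

At this position the compounds shown cover only chloro and hydrogen, so it remains open whether an amine, a carboxylic acid or a longer chain there would give a step beyond the scatter. From the compounds shown here alone, it also remains open whether the same exchange would stay within the scatter with hydrogen, rather than the fluoro group, on the ring.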